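This account rests on a few compounds, and the source may have more. Where it says the series, first, only, none or still open, it means among the compounds named here.

Two compounds share a core built around a piperidine carrying a pyridine amide and a benzyl group with two ethoxy groups. Compound 1 is `CCOc1cc(CN2CCC(NC(=O)c3ccc(N)nc3)CC2)cc(OCC)c1-c1ccc(F)cc1` and compound 2 is `CCOc1cc(CN2CCC(NC(=O)c3cncc(C)c3)CC2)cc(OCC)c1Cl`. In a physicochemical assay for lipophilicity, read by spectrophotometry, measured as octanol-water partition, at pH 7.4 (on this read-out higher numbers stand for higher lipophilicity and lower numbers for lower lipophilicity), compound 1 gives 3.15, and compound 2 gives 3.43. The two numbers lie within the usual scatter of each other, so nothing can be said of any gap between compound 2 and compound 1; compound 2 simply stands at one end of the pair of values obtained so far.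

Compound 3 is `CCOc1cc(CN2CCC(NC(=O)c3cncc(C)c3)CC2)cc(OCC)c1-c1ccc(OC(F)(F)F)cc1`, not yet measured in this assay. It differs from compound 2 in one place: 4-(trifluoromethoxy)phenyl in place of chloro on an aromatic carbon. Among the measured compounds shown here, no pair of measured compounds differing in only one place is available, so no measured step can guide the reading. Given that compound 2 sits at 3.43, a step well beyond the scatter and upward is expected from compound 2 to compound 3, about a number 1.27 log units higher from compound 2 to compound 3 (beyond the scatter). Compound 3 is therefore estimated at 4.7 in this assay, most likely between 4 and 5.4.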

Compound 3, distribution coefficient: > 4
Compound 3: no number, only a limit (the forecaster's own chance of this, stated with the estimate: 15%); the middle value lies beyond the limit too.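

In this assay compound 3 gives > 4, which is a limit of the assay and not a number. Among the compounds shown here, this is the first change in a single place that can be read in this set: putting 4-(trifluoromethoxy)phenyl in place of chloro on the aromatic carbon ortho to two ethoxy groups gives a number at least 0.57 log units higher from compound 2 to compound 3 (beyond the scatter), so this position can carry a much larger group with a clear upward shift on this read-out. The full size of that shift remains unknown, and only its lower bound can be stated: the limit of > 4 in this assay, at which 1 of the 3 values shown sits.

For the compounds shown here, compound 1 differs from compound 3 in more than one place, so it offers no clean comparison, and the single step available cannot show whether the added ring or the trifluoromethoxy group on it accounts for the shift. Going by these compounds, it also remains open how this same position would read with a plain phenyl, an amine or a carboxylic acid in place of chloro, and whether any such group would bring the value back within the range where the assay returns a number.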